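This account rests on a few compounds, and the source may have more. Where it says the series, first, only, none or still open, it means among the compounds named here.

Of the compounds shown here, three built on one shared core have been tested in a functional assay on WI-38 VA13 cells (Homo sapiens) for cytotoxicity; a higher number here means that more compound is needed for the effect, a lower number that less compound is needed. Compound 1 `Cc1c(C(=O)c2ccc(Oc3ccccc3)cc2)oc2cc(-c3ccccc3)cc(O)c12` reaches only the limit of this assay, giving > 4 ug/mL. Compound 2 `Cc1c(C(=O)c2ccc(CN(C)C)cc2)oc2cc(-c3ccccc3)cc(O)c12` likewise sits at the limit, with > 4 ug/mL. Compound 3 `Cc1c(C(=O)CCc2ccccc2)oc2cc(-c3ccccc3)cc(O)c12` also gives only a limit, > 4 ug/mL. Among the measured compounds shown here, the single step between measured compounds that differ in one place, a step that the two limits leave unreadable from compound 1 to compound 2, cannot be read in size, as both of its ends are limits. What unites the three measured compounds is the limit of > 4 ug/mL in this assay, at which 3 of the 3 values shown sit. Compound 4 `Cc1c(C(=O)c2ccc(N(C)C)cc2)oc2cc(-c3ccccc3)cc(O)c12` has not yet been measured; it differs from compound 3 by 4-(dimethylamino)phenyl in place of phenethyl on a carbonyl carbon. For the measured compounds named here, no measured step gives a number for a change on the carbonyl carbon, and the only guide is that every value obtained so far sits at the limit. The step that the limit leaves unreadable from compound 3 to compound 4 is therefore expected to stay within the scatter, most likely ending in a further limit. Compound 4 is estimated at 8 ug/mL, with a range from 4 ug/mL to 30 ug/mL.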

Compound 4, half-maximal effective concentration: > 4 ug/mL
Compound 4 ended at the assay's limit; the forecaster's own chance of this, stated with the estimate: 75%; the middle value is on the limit's open side.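

In this assay compound 4 gives the limit > 4 ug/mL as well. Its steps from compound 1, compound 2 and compound 3 cannot be read in size. All four compounds share one result: the limit of > 4 ug/mL in this assay, at which 4 of the 4 values shown sit. The compounds shown leave open how much compound each one needs for the effect, and whether they differ at all.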